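Swapping methoxy for chloro in a weakly cytotoxic series

The source may report more compounds than this note shows. Statements on the series, on what has been measured and on what is new or still open speak of the compounds shown alone.

Of the compounds shown here, three sharing one core have been tested in a functional assay on PC-3 cells (Homo sapiens) for cytotoxicity; a lower number here means a stronger inhibitor, a higher number a weaker inhibitor. Compound 1 `O=C(N/N=C\c1cn(Cc2ccc(Cl)cc2)c2cc(F)ccc12)c1c[nH]c2ccccc12` gives 19500 nM. Within the data shown here, compound 2 `Cn1cc(C(=O)N/N=C\c2cn(Cc3ccc(Cl)cc3)c3cc(F)ccc23)c2ccccc21` gives 22100 nM; the step of a 1.1-fold higher number from compound 1 to compound 2 (0.05 log units; within the scatter) is the only single-point change measured so far. Compound 3 `COc1ccc(Cn2cc(/C=N\NC(=O)c3c[nH]c4ccc(Br)cc34)c3ccc(F)cc32)cc1` gives 21800 nM. Its number stands second highest of the three, within the scatter of both compound 2 and compound 1, so no ordering among them can be claimed.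

Compound 4 `O=C(N/N=C\c1cn(Cc2ccc(Cl)cc2)c2cc(F)ccc12)c1c[nH]c2ccc(Br)cc12` differs from compound 3 by chloro in place of methoxy on an aromatic carbon: the 4-methoxybenzyl becomes a 4-chlorobenzyl. Among the measured compounds shown here, no measured step covers this exchange; compounds 1 and 2 already carry the 4-chlorobenzyl, but each also differs from compound 3 elsewhere. For the measured compounds named here, the only measured step, a 1.1-fold higher number from compound 1 to compound 2 (0.05 log units; within the scatter), lay within the scatter, and all three numbers sit close together. The step of a 1.1-fold lower number from compound 3 to compound 4 (0.04 log units; within the scatter) is therefore expected to stay within the scatter. The estimate for compound 4 in this assay is 20000 nM, with a range from 8000 nM to 50000 nM.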

Compound 4, half-maximal inhibitory concentration: 12400 nM
Compound 4: middle estimate off by 1.6-fold (0.21 log units), on the high side; measured number inside the range.
By their numbers in this assay, from the lowest: compounds 4, 1, 3 and 2 (each within the scatter of the next).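

Swapping 4-methoxybenzyl for 4-chlorobenzyl in this assay is now measured directly (a 1.8-fold lower number from compound 3 to compound 4 (0.25 log units; within the scatter)), and this step shows that the two groups cannot be told apart at this position. The two other new comparisons also stay within the scatter: bromo in place of hydrogen on an aromatic carbon (a 1.6-fold lower number from compound 1 to compound 4 (0.20 log units; within the scatter)), and 5-bromo-1H-indol-3-yl in place of 1-methyl-1H-indol-3-yl (a 1.8-fold lower number from compound 2 to compound 4 (0.25 log units; within the scatter)). No supporting measurement is available to explain these small differences.

Going by these compounds, what remains open is whether any group at this position can move the number beyond the scatter. An amine or a carboxylic acid in place of the chloro would be a much sharper test of this position than the exchange of methoxy for chloro.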